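Trimethoxyphenyl benzimidazoles: swapping bromo for tert-butyl

The source may report more compounds than this note shows. Statements on the series, on what has been measured and on what is new or still open speak of the compounds shown alone.

Measured so far:
compound 1, `COc1cc(N(Cc2nc3ccccc3[nH]2)S(=O)(=O)c2ccccc2)cc(OC)c1OC`, 25500 nM
compound 2, `COc1cc(N(Cc2nc3ccccc3[nH]2)S(=O)(=O)c2ccccc2Cl)cc(OC)c1OC`, 34500 nM
compound 3, `COc1cc(N(Cc2nc3ccccc3[nH]2)C(=O)c2ccc(Br)cc2)cc(OC)c1OC`, 19900 nM

All three numbers come from a functional assay on PC-3 cells (Homo sapiens) for inhibition, read by MTT assay, with a stated time of 48 h; on this read-out higher numbers stand for weaker inhibition and lower numbers for stronger inhibition. Compound 3 sits at the low end of the three, but only narrowly: a 1.3-fold lower number from compound 1 to compound 3 (0.11 log units; within the scatter) and a 1.7-fold lower number from compound 2 to compound 3 (0.24 log units; within the scatter), so compound 3 is not separated from the other two in any firm way. Going by the values given here, the one remaining comparison, a 1.4-fold higher number from compound 1 to compound 2 (0.13 log units; within the scatter), likewise falls within the scatter.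

Compound 4, `COc1cc(N(Cc2nc3ccccc3[nH]2)C(=O)c2ccc(C(C)(C)C)cc2)cc(OC)c1OC`, has not yet been tested in this assay . It differs from compound 3 by one change: tert-butyl in place of bromo on an aromatic carbon. Among the compounds with values here, none of the measured steps exchanges a halogen for an alkyl group at this position, so no step bears directly on it. Within the data shown here, the nearest precedent is the change of the whole aryl group from compound 1 to compound 3 and from compound 2 to compound 3, both within the scatter. For compound 4 the expected step is therefore a 1.0-fold higher number from compound 3 to compound 4 (0.00 log units; within the scatter), with no direction assumed beyond the scatter. Compound 4 is estimated to give 20000 nM in this assay , within a range of 8000 nM to 50000 nM.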

Compound 4, half-maximal inhibitory concentration: 46000 nM
Estimate against measurement, compound 4: 2.3-fold (0.36 log units) below, within the range that was stated.
By their numbers in this assay, from the lowest: compounds 3, 1, 2 and 4 (each within the scatter of the next, the first and the last beyond it).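

In this assay, going by these compounds alone, the change of bromo to tert-butyl gives the first step in this set that lies beyond the scatter, a 2.3-fold higher number from compound 3 to compound 4 (0.36 log units; beyond the scatter), though it is a modest one. Within the data shown here, it shows that inhibition is not indifferent to what stands on this aromatic carbon, which the earlier steps, all within the scatter, could not show. Nothing available here accounts for this step.

With only bromo and tert-butyl shown at this place, one step gives no trend, and it remains open whether an amine or a carboxylic acid there would stay close to compound 3 or move towards compound 4. Going by these compounds, it is also open whether tert-butyl would give a similar step on the phenylsulfonyl group of compound 1.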